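An Ethyl Group on the Phenyl Ring of Compound 3

The source may hold more compounds than are shown below. What is called first, only, known or untested is meant among the compounds shown, and "the series" means these compounds.

Three measured compounds share one core. Compound 1 `CCCc1cc(-c2cn([C@H]3C[C@H](OC(C)=O)[C@@H](COC(C)=O)O3)c(=O)[nH]c2=O)on1` carries a propyl group on its outer aromatic ring; compound 2 `CCCCCc1cc(-c2cn([C@H]3C[C@H](OC(C)=O)[C@@H](COC(C)=O)O3)c(=O)[nH]c2=O)on1` a pentyl; compound 3 `CC(=O)OC[C@H]1O[C@@H](n2cc(-c3cc(-c4ccccc4)no3)c(=O)[nH]c2=O)C[C@@H]1OC(C)=O` a phenyl. In a functional assay on NUGC-3 cells (Homo sapiens) for cytotoxicity, read by sulforhodamine B assay, tested at 10 uM (on this read-out higher numbers stand for more inhibition at the one concentration tested (going by the name of the read-out) and lower numbers for less inhibition), compound 1 gives 89.1%, compound 2 gives 91.9%, and compound 3 gives 87.6%. The steps among them are small: a number 2.8 percentage points higher from compound 1 to compound 2 (within the scatter), a number 1.5 percentage points lower from compound 1 to compound 3 (within the scatter), and a number 4.3 percentage points lower from compound 2 to compound 3 (within the scatter). Compound 3 therefore stands alongside the other two, with no separation beyond the usual scatter.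

Compound 4 `CCc1ccc(-c2cc(-c3cn([C@H]4C[C@H](OC(C)=O)[C@@H](COC(C)=O)O4)c(=O)[nH]c3=O)on2)cc1` differs from compound 3 by ethyl in place of hydrogen on an aromatic carbon. Going by the values given here, the only measured step that adds carbons, a number 2.8 percentage points higher from compound 1 to compound 2 (within the scatter), stayed within the scatter, as did the exchange of an alkyl chain for a phenyl in both other steps. Nothing measured points to a change beyond the scatter, so the expected step of a number 0.4 percentage points higher from compound 3 to compound 4 (within the scatter) is taken as flat. Compound 4 is estimated to give 88% in this assay, with a range from 79% to 95%.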

Compound 4, a percentage reported as inhibition, at one concentration (the size of the read-out at that concentration, not a potency): 72.6%
Compound 4: middle estimate off by 15.4 percentage points, on the high side; the whole stated range lies above it.
By their numbers in this assay, from the lowest: compound 4; then compounds 3, 1 and 2 (each within the scatter of the next).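

Going by these compounds alone, on the phenyl ring of compound 3, the position para to a large group turns out to respond in this assay: ethyl in place of hydrogen gives a number 15 percentage points lower from compound 3 to compound 4 (beyond the scatter) and moves the value beyond the scatter, which no step among the earlier compounds did. The 4-ethylphenyl group also separates from both alkyl chains, with a number 19.3 percentage points lower from compound 2 to compound 4 (beyond the scatter) and a number 16.5 percentage points lower from compound 1 to compound 4 (beyond the scatter), although phenyl itself did not. Added carbons therefore do not read the same everywhere, since the longer chain gave only a number 2.8 percentage points higher from compound 1 to compound 2 (within the scatter) and this ring position gave a clear fall. Nothing available accounts for this difference.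

As far as these compounds go, whether the fall belongs to ethyl alone or to any group on this carbon stays open. A methyl, a methoxy, a chlorine or a longer chain at the same place would begin to show how far it extends.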